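From 4-fluorobenzyl to 2-fluorobenzyl in a cytotoxicity series

A few compounds are considered here, and "the series" means these few. Any claim that something is new, unique, unknown or untested is made for them only; others in the source may bear on it.

Measured in a functional assay on SGC-7901 cells (Homo sapiens) for cytotoxicity, read by MTT assay, with a stated time of 48 h; on this read-out higher numbers stand for weaker inhibition and lower numbers for stronger inhibition:
Compound 1, `O=c1ccoc2cc(OCc3cn(Cc4cccc(Br)c4)nn3)ccc12`, gives > 100000 nM, which is a limit of the assay and not a number.
Compound 2, `O=c1ccoc2cc(OCc3cn(Cc4ccc(F)cc4)nn3)ccc12`, gives > 100000 nM, again a limit rather than a number.

Among the compounds with values here, compound 2 therefore stands at the limit of this assay, and the only comparison at hand, a step that the two limits leave unreadable from compound 1 to compound 2, cannot be read, since the limit of > 100000 nM in this assay, at which 2 of the 2 values shown sit, applies to both values. Nothing in these two results separates the two compounds.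

Compound 3, `O=c1ccoc2cc(OCc3cn(Cc4ccccc4F)nn3)ccc12`, has not yet been measured. It differs from compound 2 only in this: 2-fluorophenyl in place of 4-fluorophenyl on a saturated chain carbon bound to an aromatic nitrogen. Within the data shown here, no measured step bears on such a change, so there is no basis to expect a move in either direction beyond the scatter of this assay. The most that can be said is that compound 2 sits at the limit, and a small rearrangement of the same atoms is expected to leave compound 3 near it.

Compound 3 is expected to give about 150000 nM in this assay, within 40000 nM to 600000 nM, and most likely again only as a limit. The step this implies, a step that the limit leaves unreadable from compound 2 to compound 3, is expected to be within the scatter.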

Compound 3, half-maximal inhibitory concentration: > 100000 nM
Compound 3: a limit, no number; the forecaster's own chance of this, stated with the estimate: 85%; the middle value does not contradict the limit.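

Compound 3, like compound 1 and compound 2, gives a limit rather than a number in this assay, so the steps to compound 3 from compound 1 and compound 2 cannot be read: the limit of > 100000 nM in this assay, at which 3 of the 3 values shown sit.

The compounds shown leave open how the 3-bromophenyl, 4-fluorophenyl and 2-fluorophenyl groups truly compare, and whether any group in this place gives a measurable value.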